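This account rests on a few compounds, and the source may have more. Where it says the series, first, only, none or still open, it means among the compounds named here.

Measured so far in a functional assay on HCT-116 cells (Homo sapiens), read by MTT assay, with a stated time of 72 h; on this read-out higher numbers stand for weaker inhibition and lower numbers for stronger inhibition:
compound 1 `COc1nc(N)nc2c1c(-c1cc3ccccc3o1)cn2[C@@H]1O[C@H](CO)[C@@H](O)[C@H]1O`: > 20000 nM
compound 2 `COc1ncnc2c1c(I)cn2[C@@H]1O[C@H](CO)[C@@H](O)[C@H]1O`: > 20000 nM
compound 3 `Nc1nc2c(c(-c3ccccc3)cn2[C@@H]2O[C@H](CO)[C@@H](O)[C@H]2O)c(=O)[nH]1`: > 20000 nM

Each of these is a limit of this assay, not a number. For compound 2 the value > 20000 nM means only that inhibition was too weak to be measured. Going by the values given here, compound 2 therefore stands where every value so far sits: the limit of > 20000 nM in this assay, at which 3 of the 3 values shown sit. Among the compounds with values here, no two measured compounds differ in just one place, so no step size can be read from them. Compound 4 `COc1ncnc2c1c(-c1ccccc1)cn2[C@@H]1O[C@H](CO)[C@@H](O)[C@H]1O` differs from compound 2 by phenyl in place of iodo on an aromatic carbon. With nothing to suggest otherwise, the step of an at least 1.1-fold lower number from compound 2 to compound 4 (0.04 log units; that floor lies within the scatter) is expected to remain within the usual scatter. Compound 4 is estimated at 18000 nM, with a range from 6000 nM to 40000 nM, and a limit is the most likely outcome.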

Compound 4, half-maximal inhibitory concentration: > 20000 nM
Compound 4 was reported as a limit; the forecaster's own chance of this, stated with the estimate: 65%; at least 1.1-fold (0.04 log units) between middle value and limit.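

Compound 2 and compound 4 both give a limit rather than a number, so no step can be read for phenyl in place of iodo: the limit of > 20000 nM in this assay, at which 4 of the 4 values shown sit.

The compounds shown leave open what structural change, if any, would give a measurable value.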